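Swapping the Pyrazole for a Dimethylamide: Solubility Outlook

The source may hold more compounds than are shown below. What is called first, only, known or untested is meant among the compounds shown, and "the series" means these compounds.

compound 1 `COc1ccc(-c2cc(-c3ccc(NS(C)(=O)=O)cc3)cnc2N)cn1`: 25 ug/mL
compound 2 `COc1ccc(-c2cc(-c3ccc(-n4cccn4)cc3)cnc2N)cn1`: 3.1 ug/mL

In a physicochemical assay for solubility, read by nephelometry, in phosphate buffer, measured as kinetic solubility, at pH 6.5 (on this read-out higher numbers stand for higher solubility and lower numbers for lower solubility), compound 1 gives 25 ug/mL and compound 2 gives 3.1 ug/mL, so compound 2 stands lowest of the two numbers, beyond the scatter. Compound 3 `COc1ccc(-c2cc(-c3ccc(C(=O)N(C)C)cc3)cnc2N)cn1` differs from compound 2 in one place: dimethylcarbamoyl in place of 1H-pyrazol-1-yl on an aromatic carbon. Among the compounds with values here, no measured step covers this exact exchange. Within the data shown here, the one step available, an 8.1-fold lower number from compound 1 to compound 2 (0.91 log units; beyond the scatter), shows that replacing 1H-pyrazol-1-yl on an aromatic carbon by a different group moved this assay well beyond the scatter, so an upward step of comparable order seems plausible here too. Compound 3 is therefore expected to give 12 ug/mL, with a range of 4 ug/mL to 40 ug/mL. This estimate means an expected 3.9-fold higher number from compound 2 to compound 3 (0.59 log units; beyond the scatter).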

Compound 3, solubility: > 100 ug/mL
Compound 3 gave a limit, no number; the forecaster's own chance of this, stated with the estimate: 5%; at least 8.3-fold (0.92 log units) between middle value and limit.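

In this assay, dimethylcarbamoyl at this position on the aromatic ring outdoes both earlier groups, with an at least 32-fold higher number from compound 2 to compound 3 (1.50 log units; beyond the scatter) and an at least 4.0-fold higher number from compound 1 to compound 3 (0.60 log units; beyond the scatter). Since 1H-pyrazol-1-yl and dimethylcarbamoyl each hold 5 heavy atoms, a swap that leaves this count unchanged can still move the reading a long way. For compound 3, > 100 ug/mL is a limit of the assay and not a number, so the true size of both steps remains unknown: the limit of > 100 ug/mL in this assay, at which 1 of the 3 values shown sits.

Going by these compounds, how a primary amide, an amine or a carboxylic acid would read at this position remains open.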